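The source may report more compounds than this note shows. Statements on the series, on what has been measured and on what is new or still open speak of the compounds shown alone.

The measured compounds:
compound 1, `CCCCCCCCc1c(O)cc(C)oc1=O`, gives 145000 nM in an ADME assay on L929 cells (Mus musculus, culture collection number NCTC 929) for cytotoxicity, read by MTT assay, with a stated time of 72 h; on this read-out higher numbers stand for weaker inhibition and lower numbers for stronger inhibition.
compound 2, `CCCCCCNC(=O)c1c(O)cc(C)oc1=O`, gives 196000 nM in this assay.
compound 3, `CCCCCCCCCCCCCCNC(=O)c1c(O)cc(C)oc1=O`, gives no number in this assay but only a limit of the assay, > 200000 nM.

Compound 1 holds the lower of the two numbers, yet its gap to compound 2 lies within the scatter, so the two cannot be ranked; the third value is a limit. Compound 4, `CCCCCCCCCCCCCCc1c(O)cc(C)oc1=O`, differs from compound 1 by hexyl in place of hydrogen on a saturated chain carbon, eight bonds along the chain from an aromatic carbon. Within the data shown here, the one measured step that resembles this change, a chain extension on the shared core, is an at least 1.0-fold higher number from compound 2 to compound 3 (0.00 log units; that floor lies within the scatter), which read as no shift beyond the scatter. That step ends in a limit, recorded as the limit of > 200000 nM in this assay, at which 1 of the 3 values shown sits. A hexyl extension of the chain of compound 1 is therefore expected to shift this assay little, if at all, with some chance that compound 4 also reaches the limit rather than a number. The estimate for compound 4 is 180000 nM, with a range from 90000 nM to 320000 nM, an expected step of a 1.2-fold higher number from compound 1 to compound 4 (0.09 log units; within the scatter).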

Compound 4, half-maximal inhibitory concentration: 24100 nM
Estimate against measurement, compound 4: 7.5-fold (0.87 log units) above; the whole stated range lies above it.
By their numbers in this assay, from the lowest: compound 4; then compounds 1 and 2 (each within the scatter of the next). At a limit, above all of these: compound 3.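

In this assay, extending the chain on the shared core does move the read-out: hexyl in place of hydrogen on a saturated chain carbon, eight bonds along the chain from an aromatic carbon, gives a 6.0-fold lower number from compound 1 to compound 4 (0.78 log units; beyond the scatter). The earlier compounds shown here did not show this, as none of their values gave a chain extension a shift beyond the scatter. Compound 3 gives only a limit and not a number, so the size of its chain extension cannot be set against this step: the limit of > 200000 nM in this assay, at which 1 of the 4 values shown sits.

The compounds shown leave open whether a longer chain than the one in compound 4 would lower the number further. They also leave open how an amine or a carboxylic acid in place of the added hexyl would read in this assay.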